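Halogen swaps on the aryl ring leave cytotoxicity unchanged

A few compounds are considered here, and "the series" means these few. Any claim that something is new, unique, unknown or untested is made for them only; others in the source may bear on it.

Three hydrazones sharing one core were measured in a functional assay on HepG2 cells (Homo sapiens) for cytotoxicity, read by MTT assay, with a stated time of 48 h; on this read-out higher numbers stand for weaker inhibition and lower numbers for stronger inhibition. Compound 1 `O=C(CSc1nnc(-c2ccncc2)o1)N/N=C/c1ccc(Cl)cc1` gives 15700 nM, compound 2 `O=C(CSc1nnc(-c2ccncc2)o1)N/N=C/c1cccc(F)c1` gives 19500 nM, and compound 3 `O=C(CSc1nnc(-c2ccncc2)o1)N/N=C/c1ccccc1F` gives 16000 nM. Compound 3 holds the second highest of the three numbers, but all three sit within the scatter of one another: a 1.2-fold higher number from compound 1 to compound 2 (0.09 log units; within the scatter), a 1.0-fold higher number from compound 1 to compound 3 (0.01 log units; within the scatter) and a 1.2-fold lower number from compound 2 to compound 3 (0.09 log units; within the scatter). Moving the halogen around the phenyl ring, or exchanging chlorine for fluorine, thus produced no step beyond the scatter in this assay.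

Compound 4 `O=C(CSc1nnc(-c2ccncc2)o1)N/N=C/c1ccc(O)c(O)c1` is not yet measured. It differs from compound 3 in one place: 3,4-dihydroxyphenyl in place of 2-fluorophenyl on a carbon with a double bond to nitrogen. Among the compounds with values here, none of the measured steps bears directly on this change, since each of them only exchanges one halogenated phenyl for another; the new ring brings two hydroxyl groups instead. The measured steps show only that this position tolerated small changes without any shift in the number. Going by these compounds, on that basis compound 4 is expected to give a number close to that of compound 3, a 1.1-fold lower number from compound 3 to compound 4 (0.06 log units; within the scatter), with wide uncertainty because the hydroxyl change is untested here. The estimate for compound 4 is 14000 nM, within a range of 5000 nM to 40000 nM.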

Compound 4, half-maximal inhibitory concentration: 760 nM
Compound 4: middle estimate off by 18-fold (1.27 log units), on the high side; measured number outside the range, below it.
By their numbers in this assay, from the lowest: compound 4; then compounds 1, 3 and 2 (each within the scatter of the next).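

The position that looked indifferent to halogen swaps turns out to be highly sensitive to what the ring carries: in this assay, the change to 3,4-dihydroxyphenyl gives a 21-fold lower number from compound 3 to compound 4 (1.32 log units; beyond the scatter), and the same replacement gives a 26-fold lower number from compound 2 to compound 4 (1.41 log units; beyond the scatter) and a 21-fold lower number from compound 1 to compound 4 (1.32 log units; beyond the scatter). All three steps are large and beyond the scatter, so compound 4 stands apart from all three halogenated compounds, whereas the steps among those compounds had stayed within the scatter. The earlier flatness therefore held only for exchanges among halogenated phenyl rings, and nothing in these data explains the gain seen with the entering ring, which brings hydrogen-bond donors and acceptors that the leaving ring lacks.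

With only compound 4 carrying hydroxyl groups, the compounds shown leave open whether both are needed, or whether a phenyl ring with a single hydroxyl would give a similar number. They also leave open whether methoxy groups in place of the hydroxyls, or an amine or a carboxylic acid on the ring, would keep the low number seen for compound 4.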